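Methyl Addition on an Indole Ring: Predicting Compound 4

A few compounds are considered here, and "the series" means these few. Any claim that something is new, unique, unknown or untested is made for them only; others in the source may bear on it.

Measured compounds:
compound 1, `COC(=O)[C@@]1(C)CCC=C2[C@@H]1CC[C@@H](C)[C@]2(C)Cc1c[nH]c2ccc(C)cc12`, 22000 nM
compound 2, `COC(=O)[C@@]1(C)CCC=C2[C@@H]1CC[C@@H](C)[C@]2(C)Cc1c(C)[nH]c2ccc(C)cc12`, 28000 nM
compound 3, `COC(=O)[C@@]1(C)CC[C@@H]2C3=C1CC[C@@H](C)[C@]3(C)Cc1c2[nH]c2ccccc12`, 4000 nM

All three compounds were tested in a functional assay on WiDr cells (Homo sapiens) for inhibition, read by sulforhodamine B assay, with a stated time of 48 h; on this read-out higher numbers stand for weaker inhibition of growth and lower numbers for stronger inhibition of growth. Compound 1 gives 22000 nM in this assay, and compound 2 gives 28000 nM. The change between them is methyl in place of hydrogen on an aromatic carbon, and it made a step of a 1.3-fold higher number from compound 1 to compound 2 (0.10 log units; within the scatter). Compound 3, built on a different core, gives 4000 nM, the lowest number of the three; the difference between its core and that of compound 1 is not broken down here.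

Compound 4, `COC(=O)[C@@]1(C)CC[C@@H]2C3=C1CC[C@@H](C)[C@]3(C)Cc1c2[nH]c2c(C)cccc12`, has not yet been measured. It differs from compound 3 by methyl in place of hydrogen on an aromatic carbon. This is the same kind of change as that from compound 1 to compound 2, but not the same: there the methyl entered a five-membered aromatic ring with one nitrogen, next to the ring nitrogen and next to the ring atom that bears a large group, whereas here it enters a six-membered aromatic ring of carbon only, ortho to a fused ring and meta to a fused ring.

Because the earlier step was a 1.3-fold higher number from compound 1 to compound 2 (0.10 log units; within the scatter), the step from compound 3 to compound 4 is expected to be small as well, about a 1.3-fold higher number from compound 3 to compound 4 (0.10 log units; within the scatter). Compound 4 is therefore estimated to give 5000 nM in this assay, with a plausible range from 2000 nM to 14000 nM.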

Compound 4, concentration for 50% growth inhibition: 22000 nM
Compound 4: the middle estimate sits 4.4-fold (0.64 log units) below what was measured, and the stated range ends below it.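

In this assay, methyl in place of hydrogen on an aromatic carbon of the six-membered aromatic ring of carbon only gave a 5.5-fold higher number from compound 3 to compound 4 (0.74 log units; beyond the scatter), so on the core of compound 3 this small change weakened growth inhibition by a margin that can be read. The same kind of change therefore did not carry over from one core to the other at the same size, and a step seen on the core of compound 1 was no safe guide to the step on the core of compound 3: the same change on two cores in this assay, a 1.3-fold higher number (0.10 log units; within the scatter) from compound 1 to compound 2 and a 5.5-fold higher number (0.74 log units; beyond the scatter) from compound 3 to compound 4, 4.3-fold (0.64 log units) apart, beyond the scatter of two such steps. What this does not show is that the core alone sets the size of the step, since the methyl also entered a different ring in each pair, a five-membered aromatic ring with one nitrogen in compound 2 and a six-membered aromatic ring of carbon only in compound 4, and two pairs cannot separate these two differences or give a rule for the series.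

From the compounds shown here alone, it remains open whether a methyl on the five-membered aromatic ring of the core of compound 3 would give a step closer to that seen from compound 1 to compound 2. Going by these compounds, it is also open whether an ethyl group, a methoxy group or a chlorine atom on the aromatic carbon that carries the methyl in compound 4 would shift the number as far as the methyl does.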